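A few compounds are considered here, and "the series" means these few. Any claim that something is new, unique, unknown or untested is made for them only; others in the source may bear on it.

Values in an ADME assay on J774 cells (Mus musculus) for cytotoxicity; a higher number here means that more compound is needed for the effect, a lower number that less compound is needed:
- compound 1 `COC(=O)c1c[nH]c2ccccc2c1=O`: > 20000 nM
- compound 2 `COC(=O)c1c[nH]c2ccc(C(C)C)cc2c1=O`: > 20000 nM

Compound 2 stands at > 20000 nM, which is a limit of the assay and not a number. Compound 1 also gives a limit, > 20000 nM. So the record in this assay consists of the limit of > 20000 nM in this assay, at which 2 of the 2 values shown sit.

Compound 3 `COC(=O)c1c[nH]c2ccc(Cl)cc2c1=O` has chloro in place of isopropyl on an aromatic carbon. Going by the values given here, the only measured step that bears on this change is a step that the two limits leave unreadable from compound 1 to compound 2, with isopropyl in place of hydrogen, and it gives no size to carry over. With compound 1 and compound 2 both at the limit of > 20000 nM in this assay, at which 2 of the 2 values shown sit, no step beyond the scatter is expected in this assay, and a further limit is the likeliest result. The expected move is a step that the limit leaves unreadable from compound 2 to compound 3. For compound 3 the estimated value is 25000 nM, with an expected range of 12000 nM to 50000 nM.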

Compound 3, half-maximal effective concentration: > 20000 nM
Compound 3: no number, only a limit; the forecaster's own chance of this, stated with the estimate: 85%; the middle value lies beyond the limit too.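

In this assay compound 3 gives > 20000 nM, which is a limit of the assay and not a number. The steps among compound 1, compound 2 and compound 3 cannot be read. The compounds shown leave open whether hydrogen, isopropyl or chloro on that aromatic carbon makes any difference in this assay.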